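Swapping Methoxy for Bromo on the Shared Core

A few compounds are considered here, and "the series" means these few. Any claim that something is new, unique, unknown or untested is made for them only; others in the source may bear on it.

Of the compounds shown here, three built on the same core have so far been tested in a functional assay on DU-145 cells (Homo sapiens) for cytotoxicity; a lower number here means a stronger inhibitor, a higher number a weaker inhibitor. Compound 1, `COc1ccc2c(c1)c(/C=N\NC(=O)c1c[nH]c3ccc(Br)cc13)cn2Cc1ccc(Cl)cc1`, gives 57000 nM. Compound 2, `COc1ccc2c(c1)c(/C=N\NC(=O)c1cn(C)c3ccccc13)cn2Cc1ccc(Cl)cc1`, gives 93000 nM. Compound 3, `COc1ccc2c(c1)c(/C=N\NC(=O)c1c[nH]c3ccccc13)cn2Cc1ccc(Cl)cc1`, gives 50000 nM. On paper the number for compound 3 is the smallest of the three, yet the step of a 1.1-fold lower number from compound 1 to compound 3 (0.06 log units; within the scatter) and the step of a 1.9-fold lower number from compound 2 to compound 3 (0.27 log units; within the scatter) both fall within the scatter, as does a 1.6-fold higher number from compound 1 to compound 2 (0.21 log units; within the scatter), so the three compounds cannot truly be told apart in this assay.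

Compound 4, `O=C(N/N=C\c1cn(Cc2ccc(Cl)cc2)c2ccc(Br)cc12)c1c[nH]c2ccccc12`, has not yet been measured. It differs from compound 3 in one place: bromo in place of methoxy on an aromatic carbon. Among the measured compounds shown here, no measured step swaps exactly these two groups. The nearest guide is a 1.1-fold lower number from compound 1 to compound 3 (0.06 log units; within the scatter), in which a bromo on an aromatic carbon elsewhere in the molecule came and went without any effect beyond the scatter; the remaining two steps concern a methyl on an aromatic nitrogen and were also flat. Since every change tried so far has left the number essentially unmoved, no step beyond the scatter is expected for compound 4: no change at the digits printed from compound 3 to compound 4 (within the scatter). The estimated value for compound 4 is 50000 nM, with a likely range from 20000 nM to 130000 nM.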

Compound 4, half-maximal inhibitory concentration: 3600 nM
Compound 4: middle estimate off by 14-fold (1.14 log units), on the high side; measured number below the stated range.
By their numbers in this assay, from the lowest: compound 4; then compounds 3, 1 and 2 (each within the scatter of the next).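

In this assay, among the compounds shown here, the aromatic carbon carrying the methoxy group, on the six-membered aromatic ring of carbon only, is the first place where a single change moves the number beyond the scatter: bromo in place of methoxy gives a 14-fold lower number from compound 3 to compound 4 (1.14 log units; beyond the scatter), and compound 4 stands apart from the other three compounds. The position of a group matters here, since a bromo elsewhere in the molecule, on the group attached to the carbonyl carbon, gave only a 1.1-fold lower number from compound 1 to compound 3 (0.06 log units; within the scatter), so the same atom has a large effect in one place and none that can be read in the other. The data offer no measurement that explains why this swap has such a large effect.

From the compounds shown here alone, with only methoxy and bromo compared at this position, it remains open whether the drop belongs to bromo itself or to the loss of methoxy, and whether another group there, such as chloro, an amine or a longer chain, would do the same. Going by these compounds, it is also open whether this bromo would add to the second bromo carried by compound 1 or to the methyl on the aromatic nitrogen of compound 2.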